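Trading a hydroxy group for a fluoro group

This account rests on a few compounds, and the source may have more. Where it says the series, first, only, none or still open, it means among the compounds named here.

In a functional assay on HL-60 cells (Homo sapiens) for cytotoxicity, read by WST assay, with a stated time of 48 h (a lower number here means a stronger inhibitor, a higher number a weaker inhibitor), compound 2 `Oc1cccc(/C=C/C[C@H]2C[C@@H]([C@@H](O)c3ccccc3)CO[C@@H]2c2ccccc2)c1` gives 12800 nM. Compound 1 `O[C@@H](c1ccccc1)[C@H]1CO[C@H](c2ccccc2)[C@@H](C/C=C/c2cccc(F)c2)C1` gives 9170 nM, and these two values lie within the scatter of each other, so compound 2 stands level with compound 1. Compound 3 `O[C@@H](c1ccccc1)[C@H]1CO[C@H](c2ccccc2)[C@@H](C/C=C/c2ccc(F)cc2)C1` has not yet been measured. It differs from compound 2 in one place, on a double-bonded chain carbon bound to a double-bonded chain carbon: 4-fluorophenyl in place of 3-hydroxyphenyl on a double-bonded chain carbon bound to a double-bonded chain carbon. Among the compounds with values here, the one measured step that bears on this change is a 1.4-fold higher number from compound 1 to compound 2 (0.14 log units; within the scatter), which put hydroxy in place of fluoro on an aromatic carbon and stayed within the scatter. Within the data shown here, no measured compound carries the 4-fluorophenyl group, so this single step is a thin guide. No shift beyond the scatter is expected in this assay, and no direction is favoured. The expected step is a 1.2-fold lower number from compound 2 to compound 3 (0.09 log units; within the scatter). For compound 3 the estimated value is 10500 nM, with a likely range of 5500 nM to 20000 nM.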

Compound 3, half-maximal inhibitory concentration: 8110 nM
The estimate for compound 3 lay 1.3-fold (0.11 log units) above the measured number; low and high end bracket the measured number.
By their numbers in this assay, from the lowest: compounds 3, 1 and 2 (each within the scatter of the next).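

In this assay, putting 4-fluorophenyl in place of 3-hydroxyphenyl gives a 1.6-fold lower number from compound 2 to compound 3 (0.20 log units; within the scatter), so a group with no hydrogen-bond donor or acceptor stands level with one that has one of each. Putting 4-fluorophenyl in place of 3-fluorophenyl gives a 1.1-fold lower number from compound 1 to compound 3 (0.05 log units; within the scatter), so this first comparison of the two fluorophenyl groups also shows no difference beyond the scatter. No supporting measurement is available to explain why these changes leave the values level.

Still open, as far as these compounds go, is whether 4-hydroxyphenyl would match 3-hydroxyphenyl at this place, which would test the hydroxy group in the same way as the fluoro pair. Also open, from the compounds shown here alone, is whether an amine or a carboxylic acid on the aromatic ring, or a longer chain in place of prop-2-en-1-yl, would move the number beyond the scatter.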